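Aryl group in place of cyclohexylsulfanyl: expectation for compound 4

The source may hold more compounds than are shown below. What is called first, only, known or untested is meant among the compounds shown, and "the series" means these compounds.

Values in an assay on CHO cells for antagonist activity at transient receptor potential cation channel subfamily V member 1 (Homo sapiens), read by FLIPR; a higher number here means a weaker inhibitor, a lower number a stronger inhibitor:
compound 1 `CC(C(=O)NCc1ccc(C(F)(F)F)cc1N1CCC(C(F)(F)F)CC1)c1ccc(NS(C)(=O)=O)c(F)c1`: 0.4 nM
compound 2 `CC(C)COc1cc(C(F)(F)F)ccc1CNC(=O)C(C)c1ccc(NS(C)(=O)=O)c(F)c1`: 0.8 nM
compound 3 `CC(C(=O)NCc1ccc(C(F)(F)F)cc1SC1CCCCC1)c1ccc(NS(C)(=O)=O)c(F)c1`: 0.5 nM

Compound 3 stands second highest of the three numbers; its nearest neighbour is compound 1, a 1.3-fold higher number from compound 1 to compound 3 (0.10 log units; within the scatter), and the wider gap is to compound 2, a 1.6-fold lower number from compound 2 to compound 3 (0.20 log units; within the scatter). All three compounds share one core and differ only in the substituent on the aromatic carbon that carries the cyclohexylsulfanyl group in compound 3.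

Compound 4 `CC(C(=O)NCc1ccc(C(F)(F)F)cc1-c1ccc(F)c(Cl)c1)c1ccc(NS(C)(=O)=O)c(F)c1` continues this exchange: 3-chloro-4-fluorophenyl in place of cyclohexylsulfanyl on an aromatic carbon. Within the data shown here, the steps that bear on it are the three swaps at the same position, a 2.0-fold higher number from compound 1 to compound 2 (0.30 log units; within the scatter), a 1.3-fold higher number from compound 1 to compound 3 (0.10 log units; within the scatter) and a 1.6-fold lower number from compound 2 to compound 3 (0.20 log units; within the scatter), each within the scatter. Among the measured compounds shown here, no measured step introduces an aromatic ring at this carbon, so the precedent is indirect, but nothing among the three compounds suggests that this position drives the number in this assay. For compound 4 the step of a 1.2-fold higher number from compound 3 to compound 4 (0.08 log units; within the scatter) is therefore expected to lie within the scatter, with a somewhat wider range to allow for the untested ring type. Compound 4 is estimated at 0.6 nM in this assay, between 0.2 nM and 2 nM.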

Compound 4, inhibition constant: 0.6 nM
Compound 4: the middle estimate sits on the measured number at the digits printed; measured number inside the range.
By their numbers in this assay, from the lowest: compounds 1, 3, 4 and 2 (each within the scatter of the next).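

Among these compounds, with 3-chloro-4-fluorophenyl on this aromatic carbon, the series gains a six-membered aromatic ring at a position so far held by 4-(trifluoromethyl)piperidin-1-yl, isobutoxy and cyclohexylsulfanyl, and in this assay all three new steps lie within the scatter (a 1.2-fold higher number from compound 3 to compound 4 (0.08 log units; within the scatter); a 1.3-fold lower number from compound 2 to compound 4 (0.12 log units; within the scatter); a 1.5-fold higher number from compound 1 to compound 4 (0.18 log units; within the scatter)). Among these four compounds, then, an aromatic ring, a non-aromatic ring and a branched ether chain at this carbon give no step beyond the scatter. Nothing available explains why the values stay so close.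

Still open, going by these compounds, is whether this tolerance extends to a much smaller substituent, such as a methyl group or a lone fluorine, or to a carboxylic acid or a primary amine at this carbon. Also open, on these data alone, is whether a pyridine ring would behave as the 3-chloro-4-fluorophenyl ring does.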